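The source may hold more compounds than are shown below. What is called first, only, known or untested is meant among the compounds shown, and "the series" means these compounds.

Measured so far:
- compound 1, `CC(=O)NCC[C@@H]1C[C@@H](c2ccc(F)c(F)c2)[C@H](NC(=O)c2cc(-c3c(Cl)cnn3C)c(Cl)o2)CN1`: 2.49 nM
- compound 2, `Cn1ncc(Cl)c1-c1cc(C(=O)N[C@@H]2CN[C@H](CC(=O)O)C[C@H]2c2ccc(Cl)c(Cl)c2)oc1Cl`: 1.94 nM
- compound 3, `Cn1ncc(Cl)c1-c1cc(C(=O)NC2CNCC2c2ccc(C(F)(F)F)cc2)oc1Cl`: 538 nM

In an assay for inhibition of RAC-alpha serine/threonine-protein kinase (Homo sapiens), read by HTRF, with a stated time of 1 h (a lower number here means a stronger inhibitor, a higher number a weaker inhibitor), compound 1 sits in the low range of the three numbers, and its value and that of compound 2 lie within the scatter of each other, so no order between them is claimed. Compound 3 gives a far higher number, a gap well beyond the scatter; it differs from compound 1 in several places at once, so nothing in the data ties that gap to a single change.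

Compound 4, `CNC(=O)C[C@@H]1C[C@@H](c2ccc(F)c(F)c2)[C@H](NC(=O)c2cc(-c3c(Cl)cnn3C)c(Cl)o2)CN1`, is the next member. Relative to compound 1 the change is methylcarbamoyl in place of acetamidomethyl on a saturated chain carbon bound to a saturated ring carbon. Among the measured compounds shown here, both compound 1 and compound 2 carry a different substituent on the saturated chain carbon bound to the saturated ring carbon and both give low numbers, which suggests this position tolerates variation, though only two examples support that. Compound 4 is therefore expected to stay close to compound 1, with a step of a 1.4-fold higher number from compound 1 to compound 4 (0.15 log units; within the scatter) that is expected to lie within or only just beyond the scatter. The estimate for compound 4 in this assay is 3.5 nM, with a range from 1.2 nM to 10 nM.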

Compound 4, half-maximal inhibitory concentration: 1.37 nM
Beside the measured number, compound 4's estimate is 2.6-fold (0.41 log units) above it; the range from low to high includes it.
By their numbers in this assay, from the lowest: compounds 4, 2 and 1 (each within the scatter of the next); then compound 3.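

In this assay, the step to methylcarbamoyl in place of acetamidomethyl on a saturated chain carbon bound to a saturated ring carbon is a 1.8-fold lower number from compound 1 to compound 4 (0.26 log units; within the scatter). Among the compounds shown here, this is the first comparison that changes this position alone, with the rest of compound 1 held constant, and it shows that shortening the substituent from 5 heavy atoms to 4 leaves the number within the scatter. The data offered here give no measured explanation for this result.

Going by these compounds, it remains open how a terminal amine, a hydroxyl group or a chain longer than 2-acetamidoethyl would read at this position. Also unresolved is whether the position needs a substituent at all, as no single-place comparison here removes it.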